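The compounds below may be only part of what the source reports. "The series", "measured", "known", "first", "only" and "open" are said of these compounds alone.

Of the compounds shown here, three have been measured in an ADME assay on MT4 cells (Homo sapiens) for cytotoxicity, read by MTT assay, with a stated time of 4 days; a higher number here means that more compound is tolerated, a lower number that less compound is tolerated. Compound 1 `Cc1ccc(-c2c(C)c(-c3ccc(C)c(C)c3)c(C(OC(C)(C)C)C(=O)O)c(C)c2N)cc1C` gives 12000 nM in this assay. Compound 2 `Cc1ccc(-c2c(C)c(-c3ccc(C)c(C)c3)c(C(OC(C)(C)C)C(=O)O)c(C)c2NC(=O)Nc2ccccc2)cc1C` carries a phenylcarbamoyl group where compound 1 has a hydrogen on the ring nitrogen, and compound 2 gives 8000 nM; the step of a 1.5-fold lower number from compound 1 to compound 2 (0.18 log units; within the scatter) lies within the usual scatter, so the two numbers cannot be told apart. Compound 3 `Cc1ccc(-c2c(C)c(-c3ccc(Cl)cc3)c(C(OC(C)(C)C)C(=O)O)c(C)c2NS(C)(=O)=O)cc1C` gives 26000 nM, the highest of the three numbers, and its gaps to compound 1 and to compound 2 both lie beyond the scatter, so more of compound 3 is tolerated by the cells than of either other compound.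

Compound 4 `Cc1ccc(-c2c(C)c(-c3ccc(Cl)c(F)c3)c(C(OC(C)(C)C)C(=O)O)c(C)c2NS(C)(=O)=O)cc1C` differs from compound 3 by a single change: fluoro in place of hydrogen on an aromatic carbon, turning a 4-chlorophenyl group into a 4-chloro-3-fluorophenyl group. Going by the values given here, no measured pair shows this change, and the one step that has been measured concerns a different change and lies within the scatter. There is thus no basis for expecting a shift in this assay, and the expected step of no change at the digits printed from compound 3 to compound 4 (within the scatter) is estimated to be none beyond the scatter. Compound 4 is therefore expected to give about 26000 nM, with a likely range from 12000 nM to 55000 nM.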

Compound 4, half-maximal cytotoxic concentration: 22000 nM
For compound 4 the middle estimate is 1.2-fold (0.07 log units) above the measured one; low and high end bracket the measured number.
By their numbers in this assay, from the lowest: compounds 2, 1, 4 and 3 (each within the scatter of the next, the first and the last beyond it).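

Placing a fluoro on an aromatic carbon, ortho to the chloro group, gives the first measured step at this position: in this assay, the step of a 1.2-fold lower number from compound 3 to compound 4 (0.07 log units; within the scatter) is too small to separate the two numbers. For this one pair, then, the 4-chlorophenyl and 4-chloro-3-fluorophenyl groups cannot be told apart by how much compound the cells tolerate. No measurement shown offers an explanation for this result.

Going by these compounds, it remains open whether a larger group at the same position, such as a methoxy group, an amine or a carboxylic acid, would also give a number within the scatter of compound 3. A single pair also cannot show whether fluoro would behave the same way at another position on this ring.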